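Moving a methyl around the aryl group on the amide

This account rests on a few compounds, and the source may have more. Where it says the series, first, only, none or still open, it means among the compounds named here.

Three measured compounds share one core and differ only in the aryl group attached to the amide nitrogen. In a functional assay on CHO cells for antagonist activity at Orexin receptor type 2 (Homo sapiens), read by FLIPR and calcium flux (a lower number here means a stronger inhibitor, a higher number a weaker inhibitor), compound 2 `COc1ccc(C)cc1NC(=O)CSc1nnc(-c2ccoc2C)n1Cc1ccco1` gives 15.9 nM, and compound 3 `Cc1ccc(NC(=O)CSc2nnc(-c3ccoc3C)n2Cc2ccco2)cc1` gives 39.8 nM. Compound 1 `Cc1cccc(C)c1NC(=O)CSc1nnc(-c2ccoc2C)n1Cc1ccco1` gives only a limit of the assay, > 15800 nM. Of the two real numbers, compound 3 is the higher: the step is a 2.5-fold higher number from compound 2 to compound 3 (0.40 log units; beyond the scatter), a modest one, while an at least 390-fold lower number from compound 1 to compound 3 (2.59 log units; beyond the scatter) is large. Compound 4 `Cc1cccc(NC(=O)CSc2nnc(-c3ccoc3C)n2Cc2ccco2)c1` differs from compound 3 by 3-methylphenyl in place of 4-methylphenyl on an amide-type nitrogen. Within the data shown here, no measured step matches this exact move, and the two steps touching the same aryl group range from modest to large, so a modest shift in no firm direction is expected. Compound 4 is therefore estimated at 30 nM in this assay, within 8 nM to 120 nM, a step of a 1.3-fold lower number from compound 3 to compound 4 (0.12 log units; within the scatter).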

Compound 4, inhibition constant: 50.1 nM
Compound 4: middle estimate off by 1.7-fold (0.22 log units), on the low side; measured number inside the range.
By their numbers in this assay, from the lowest: compound 2; then compounds 3 and 4 (each within the scatter of the next). At a limit, above all of these: compound 1.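

Moving the methyl from 4-methylphenyl to 3-methylphenyl on the amide nitrogen makes no clear difference in this assay: the result is a 1.3-fold higher number from compound 3 to compound 4 (0.10 log units; within the scatter). Taking away the methoxy is a clearer change, a 3.2-fold higher number from compound 2 to compound 4 (0.50 log units; beyond the scatter), so among these compounds the methoxy matters more than where this single methyl sits. Measured against a limit of the assay rather than a real number, the change to 3-methylphenyl reads as an at least 310-fold lower number from compound 1 to compound 4 (2.49 log units; beyond the scatter).

On these data alone, it remains open how an amine or a carboxylic acid on this aryl group would behave in place of the methyl or the methoxy.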